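Returning to a primary amine on the thiophene-fused core

The source may report more compounds than this note shows. Statements on the series, on what has been measured and on what is new or still open speak of the compounds shown alone.

Compound 3 `c1cc2c(s1)[C@H](CN1CCCC1)OCC2` stands highest of the three measured compounds in a functional assay on CHO-K1 cells for agonist activity at trace amine-associated receptor 1 (Homo sapiens), read by HTRF and cAMP accumulation, with a stated time of 30 min (on this read-out lower numbers stand for an effect already at smaller amounts and higher numbers for an effect only at larger amounts of compound), where compound 3 gives 7200 nM. Compound 1 `NC[C@@H]1OCCc2ccsc21` gives 3.5 nM and compound 2 `CN(C)C[C@@H]1OCCc2ccsc21` gives 203 nM. The steps were a 2100-fold higher number from compound 1 to compound 3 (3.31 log units; beyond the scatter) and a 35-fold higher number from compound 2 to compound 3 (1.55 log units; beyond the scatter), with a 58-fold higher number from compound 1 to compound 2 (1.76 log units; beyond the scatter) between the two amines. Compound 4 `NCC[C@@H]1OCCc2ccsc21` is made from compound 3 by the change (aminomethyl in place of pyrrolidin-1-yl on a saturated chain carbon bound to a saturated ring carbon). Among the measured compounds shown here, the step from compound 1 to compound 3 bears directly, reversed, on this change, since a primary amine returns; only the chain differs from compound 1, which no measured step covers. A large decrease is therefore expected, a 180-fold lower number from compound 3 to compound 4 (2.26 log units; beyond the scatter), and compound 4 is estimated at 40 nM, within 5 nM to 400 nM.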

Compound 4, half-maximal effective concentration: 233 nM
The estimate for compound 4 lay 5.8-fold (0.77 log units) below the measured number, and the stated range covers the measured number.
By their numbers in this assay, from the lowest: compound 1; then compounds 2 and 4 (each within the scatter of the next); then compound 3.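

In this assay the aminomethyl group, which also ends in a primary amine, gave a 31-fold lower number from compound 3 to compound 4 (1.49 log units; beyond the scatter), but a primary amine alone did not settle the outcome at this place, as shown by a 67-fold higher number from compound 1 to compound 4 (1.82 log units; beyond the scatter). The change also gave a 1.1-fold higher number from compound 2 to compound 4 (0.06 log units; within the scatter), so the aminomethyl and dimethylamino groups cannot be told apart here. No evidence is available on what lies behind these steps. As far as these compounds go, it remains open how a methylamino group would behave at this place, and whether a longer chain ending in a primary amine would move the number further.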